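This account rests on a few compounds, and the source may have more. Where it says the series, first, only, none or still open, it means among the compounds named here.

In a physicochemical assay for solubility, read by HPLC, in phosphate buffer, at pH 6.8 (a higher number here means a more soluble compound, a lower number a less soluble compound), compound 1 `CC[C@@H]1CC[C@@H](C(=O)N2CCOCC2)N1C(=O)C1=C(C(C)C)N2C(=N[C@@](C)(c3ccc(Cl)cc3)[C@H]2c2ccc(Cl)cc2)S1` gives 9 ug/mL and compound 2 `CC(=O)N1CCN(C(=O)[C@@H]2CC[C@@H](C)N2C(=O)C2=C(C(C)C)N3C(=N[C@@](C)(c4ccc(Cl)cc4)[C@H]3c3ccc(Cl)cc3)S2)C[C@H]1C` gives 72 ug/mL, the higher of the two numbers and a gap beyond the usual scatter. These two compounds differ in more than one place, so their gap cannot be tied to any single change. Compound 3 `CC[C@@H]1CC[C@@H](C(=O)N2CCN(C(C)=O)[C@H](C)C2)N1C(=O)C1=C(C(C)C)N2C(=N[C@@](C)(c3ccc(Cl)cc3)[C@H]2c2ccc(Cl)cc2)S1` differs from compound 2 in one place: methyl in place of hydrogen on a saturated chain carbon bound to a saturated ring carbon. For the measured compounds named here, no measured pair shows this change alone. A small downward step, within the scatter, is expected: a 1.6-fold lower number from compound 2 to compound 3 (0.20 log units; within the scatter). For compound 3 the estimated value is 45 ug/mL, with an expected range of 18 ug/mL to 110 ug/mL.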

Compound 3, solubility: 25 ug/mL
The estimate for compound 3 lay 1.8-fold (0.26 log units) above the measured number; the range from low to high includes it.
By their numbers in this assay, from the lowest: compound 1; then compound 3; then compound 2.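

In this assay, methyl in place of hydrogen on a saturated chain carbon bound to a saturated ring carbon, which turns methyl into ethyl, goes with a 2.9-fold lower number from compound 2 to compound 3 (0.46 log units; beyond the scatter) and so moves the number beyond the scatter. With ethyl kept at that place, the larger ring group on the carbonyl carbon goes with a 2.8-fold higher number from compound 1 to compound 3 (0.44 log units; beyond the scatter) in the opposite direction. Nothing measured here gives a reason for either step. As far as these compounds go, whether a longer chain such as propyl lowers the number further remains open. So does whether a hydroxymethyl group at this place would follow the same direction.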